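The source may hold more compounds than are shown below. What is called first, only, known or untested is meant among the compounds shown, and "the series" means these compounds.

Working notes on the series.

Compound 2 `C=CCn1c(=O)/c(=C\c2cc(Br)ccc2F)[nH]c(=O)/c1=C\c1ccccc1OC` is the starting point for this step. In a functional assay on Huh-7 cells (Homo sapiens) for cytotoxicity, read by CCK-8 assay, with a stated time of 72 h (a lower number here means a stronger inhibitor, a higher number a weaker inhibitor), compound 2 is recorded as "not active" (no number reported), with no number attached, so nothing can be said about how far it sits from the other entries beyond the fact that it gave no measurable inhibition. Its close relative compound 1 `C=CCn1c(=O)/c(=C\c2ccc(Cl)c(Cl)c2)[nH]c(=O)/c1=C\c1ccccc1OC` is in the same position: in this assay compound 1 is also recorded as "not active" (no number reported). For the measured compounds named here, the only compound with a number is compound 3 `COc1ccccc1/C=c1\c(=O)[nH]/c(=C/c2cccc(Cl)c2Cl)c(=O)n1C`, which differs from the other two in more than one place; in this assay compound 3 gives 300 nM.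

The step to compound 4 `C=CCn1c(=O)/c(=C\c2ccc(F)c(Br)c2)[nH]c(=O)/c1=C\c1ccccc1OC` is 3-bromo-4-fluorophenyl in place of 5-bromo-2-fluorophenyl on a double-bonded chain carbon bound to an aromatic carbon, in words 3-bromo-4-fluorophenyl in place of 5-bromo-2-fluorophenyl on a double-bonded chain carbon bound to an aromatic carbon; the two compounds have the same atoms, joined differently. Going by the values given here, no pair of measured compounds shows this kind of rearrangement, and the starting point has no number, so the size of the step in this assay cannot be anchored. Both measured allyl compounds gave no activity, which points to compound 4 most probably returning no number either.

Compound 4 is expected at 20000 nM in this assay, with a range of 2000 nM to 100000 nM, the most likely outcome being another entry without a number.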

Compound 4, half-maximal inhibitory concentration: "not active" (no number reported)
Compound 4: no number reported; the estimate stays without a comparison.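

In this assay compound 4 carries no number, as does compound 2, so no step can be read between them. No measurement bearing on this result is available. The compounds shown leave open whether 3-bromo-4-fluorophenyl in place of 5-bromo-2-fluorophenyl changes the response at all.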